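Removing One Hydroxymethyl Arm: Expected Effect on Cell Growth

This account rests on a few compounds, and the source may have more. Where it says the series, first, only, none or still open, it means among the compounds named here.

Compound 1 `COCn1c(CC(O)(CO)CO)cc(=O)[nH]c1=O`: in a functional assay on SW-620 cells (Homo sapiens) for antiproliferative activity, read by MTT assay, with a stated time of 72 h (a lower number here means a stronger inhibitor, a higher number a weaker inhibitor), compound 1 gives only the limit > 100000 nM.
Compound 2 `C[Si](C)(C)CCOCn1c(CC(O)(CO)CO)cc(=O)[nH]c1=O`: in this assay compound 2 gives only the limit > 100000 nM.

Among the measured compounds shown here, compound 2 stands at the upper edge of this assay, with a limit rather than a number, and the same holds for the only other measured compound, so that the limit of > 100000 nM in this assay, at which 2 of the 2 values shown sit, is the whole of what is known. For the measured compounds named here, the single step between measured compounds, a step that the two limits leave unreadable from compound 1 to compound 2, cannot be read, since the two limits hide its size and direction. Compound 3 `C[Si](C)(C)CCOCn1c(CC(O)CO)cc(=O)[nH]c1=O` differs from compound 2 by hydrogen in place of hydroxymethyl on a saturated chain carbon bound to an oxygen on a saturated carbon and two saturated chain carbons. Going by the values given here, no measured step bears on this particular change, and the step that exists offers no size to carry over. With nothing to show that removing the hydroxymethyl arm moves the potency, compound 3 is expected to stay in the same region as its parent, which most likely means another limit reported in this assay. Compound 3 is estimated at 150000 nM, with a range from 50000 nM to 500000 nM. The expected step is a step that the limit leaves unreadable from compound 2 to compound 3, which means no change beyond the scatter.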

Compound 3, half-maximal inhibitory concentration: > 100000 nM
Compound 3: a limit, no number; the forecaster's own chance of this, stated with the estimate: 85%; the middle value lies beyond the limit too.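

The step from compound 2 to compound 3 cannot be read, since both compounds give only a limit in this assay, not a number. The compounds shown leave open whether losing the hydroxymethyl arm changes potency at all, and what change to the shared core would give a measurable value, with all of them at one edge: the limit of > 100000 nM in this assay, at which 3 of the 3 values shown sit.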